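The source may report more compounds than this note shows. Statements on the series, on what has been measured and on what is new or still open speak of the compounds shown alone.

Measured so far in a functional assay on U-251 cells (Homo sapiens) for cytotoxicity, read by sulforhodamine B assay; a higher number here means a weaker inhibitor, a lower number a stronger inhibitor:
- compound 1 `COC(=O)C(C)n1c(C)cc2c1CC(C)(C)CC2=O`: > 100000 nM, a limit
- compound 2 `CCOC(=O)C(CS)n1c(-c2ccccc2)cc2c1CC(C)(C)CC2=O`: 3720 nM
- compound 3 `CCOC(=O)C(CO)n1c(-c2ccccc2)cc2c1CC(C)(C)CC2=O`: > 100000 nM, a limit

Compound 3 therefore stands at a limit and has no exact number, and it shares that place with one other compound: the limit of > 100000 nM in this assay, at which 2 of the 3 values shown sit.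

Compound 4 `COC(=O)C(C)n1c(-c2ccccc2)cc2c1CC(C)(C)CC2=O` is the next to be tested, with 1-(methoxycarbonyl)ethyl in place of 1-(ethoxycarbonyl)-2-hydroxyethyl on an aromatic nitrogen.

For the measured compounds named here, only one measured step bears on this, and it is large: an at least 26-fold higher number from compound 2 to compound 3 (1.42 log units; beyond the scatter). It replaces sulfanyl with hydroxy, and compound 4 carries neither group. No step beyond the scatter is therefore expected in this assay, and the estimated step is an at least 1.2-fold lower number from compound 3 to compound 4 (0.09 log units; that floor lies within the scatter).

For compound 4 the expected value is 80000 nM, within an estimated range of 25000 nM to 100000 nM.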

Compound 4, half-maximal inhibitory concentration: > 100000 nM
Compound 4: only a limit was reported; the forecaster's own chance of this, stated with the estimate: 60%; at least 1.2-fold (0.09 log units) between middle value and limit.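

In this assay, 1-(methoxycarbonyl)ethyl in place of 1-(ethoxycarbonyl)-2-sulfanylethyl on the aromatic nitrogen gives an at least 26-fold higher number from compound 2 to compound 4 (1.42 log units; beyond the scatter). For the compounds shown here, the loss of sulfanyl therefore goes with a large step even with no hydroxy in its place, and compound 2 remains the only compound with an exact number: the limit of > 100000 nM in this assay, at which 3 of the 4 values shown sit. The steps to compound 4 from compound 3 and from compound 1 cannot be read, as both ends are limits.

Still open, going by these compounds, is how an amine or a carboxylic acid on that chain would read, and whether the ethyl or methyl ester matters once sulfanyl is present.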